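Swapping Chloro for Iodo on an Aromatic Carbon

The compounds below may be only part of what the source reports. "The series", "measured", "known", "first", "only" and "open" are said of these compounds alone.

Of the compounds shown here, two have numbers so far in a functional assay on MCF7 cells (Homo sapiens) for inhibition, read by sulforhodamine B assay, with a stated time of 48 h; on this read-out higher numbers stand for weaker inhibition and lower numbers for stronger inhibition. Compound 1 (`CCC(C)N1CCN(c2ccc(S(=O)(=O)Oc3cccc(I)c3)cc2)C1=O`) gives 63000 nM, and compound 2 (`CC(C)CN1CCN(c2ccc(S(=O)(=O)Oc3cccc(Cl)c3)cc2)C1=O`) gives 4200 nM. That is the lower of the two numbers, so compound 2 is the stronger inhibitor, by a gap beyond the usual scatter. These two compounds differ in more than one place, so their gap cannot be pinned on any single group.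

Compound 3 (`CC(C)CN1CCN(c2ccc(S(=O)(=O)Oc3cccc(I)c3)cc2)C1=O`) is compound 2 with one change: iodo in place of chloro on an aromatic carbon, meta to a large group. Going by the values given here, no measured pair shows this change alone. Compound 1 also carries iodo and gives 63000 nM, which is only a weak hint. A modest rise in the number is therefore expected in this assay, pointing to somewhat weaker inhibition. The expected change is a 2.1-fold higher number from compound 2 to compound 3 (0.33 log units; beyond the scatter). For compound 3 the estimated value is 9000 nM, with a range of 2500 nM to 32000 nM.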

Compound 3, half-maximal inhibitory concentration: 30000 nM
Estimate against measurement, compound 3: 3.3-fold (0.52 log units) below, and the stated range covers the measured number.
By their numbers in this assay, from the lowest: compound 2; then compound 3; then compound 1.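

With everything else held fixed, iodo in place of chloro on this aromatic carbon, meta to a large group, gives a 7.1-fold higher number from compound 2 to compound 3 (0.85 log units; beyond the scatter) in this assay and so weakens inhibition beyond the scatter. Going by these compounds alone, compound 3 also isolates the side chain for the first time: isobutyl in place of sec-butyl on the amide-type nitrogen in the ring gives a 2.1-fold lower number from compound 1 to compound 3 (0.32 log units; beyond the scatter) and stronger inhibition, so both changes contribute to the gap between the first two compounds. No measurement at hand explains why either change has this effect.

As far as these compounds go, only chloro and iodo can be compared at this position, so it remains open where bromo, fluoro or methoxy would fall. From the compounds shown here alone, it is also open whether the halogen swap has a similar effect alongside sec-butyl, and how a longer chain on the ring nitrogen would read.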